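This account rests on a few compounds, and the source may have more. Where it says the series, first, only, none or still open, it means among the compounds named here.

Series notes. Among the measured compounds shown here, compound 2 `Cc1ccc2nc(NCCCCOc3cc(O)c4c(=O)cc(-c5ccccc5)oc4c3)sc2c1` gives 48.4 ug/mL in a functional assay on SK-OV-3 cells (Homo sapiens) for cytotoxicity, read by sulforhodamine B assay, with a stated time of 48 h (a lower number here means a stronger inhibitor, a higher number a weaker inhibitor), which places it second highest of the three numbers so far, nearest compound 1 `O=c1cc(-c2ccccc2)oc2cc(OCCCCNc3nc4ccccc4s3)cc(O)c12` with 48.5 ug/mL and furthest from compound 3 `O=C(O)c1ccc2nc(NCCCCOc3cc(O)c4c(=O)cc(-c5ccccc5)oc4c3)sc2c1` with 43.3 ug/mL; all three lie within the scatter of one another. The step to compound 4 `O=c1cc(-c2ccccc2)oc2cc(OCCCCNNc3nc4ccccc4s3)cc(O)c12` is (1,3-benzothiazol-2-yl)amino in place of 6-methyl-1,3-benzothiazol-2-yl on an amine nitrogen. The measured steps each alter a substituent on an aromatic carbon, namely a 1.0-fold lower number from compound 1 to compound 2 (0.00 log units; within the scatter) and a 1.1-fold lower number from compound 2 to compound 3 (0.05 log units; within the scatter), both within the scatter. For the measured compounds named here, none of them touches the amine nitrogen, so no measured step bears directly on this change, and there is no ground to expect a step beyond the scatter in either direction. Compound 4 is therefore expected near the measured numbers, at 48 ug/mL (range 25 ug/mL to 95 ug/mL), the expected step being a 1.0-fold lower number from compound 2 to compound 4 (0.00 log units; within the scatter).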

Compound 4, half-maximal inhibitory concentration: 51.7 ug/mL
Compound 4: middle estimate off by 1.1-fold (0.03 log units), on the low side, and the stated range covers the measured number.
By their numbers in this assay, from the lowest: compounds 3, 2, 1 and 4 (each within the scatter of the next).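

Changing the group on the amine nitrogen to (1,3-benzothiazol-2-yl)amino gives steps within the scatter from each earlier compound (a 1.1-fold higher number from compound 1 to compound 4 (0.03 log units; within the scatter); a 1.1-fold higher number from compound 2 to compound 4 (0.03 log units; within the scatter); a 1.2-fold higher number from compound 3 to compound 4 (0.08 log units; within the scatter)) in this assay. This position therefore joins the aromatic carbon substituents in showing no step beyond the scatter across the four compounds. No measured evidence bears on this result.

From the compounds shown here alone, whether an acetyl group or a longer chain on this amine nitrogen would give a step beyond the scatter remains open.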